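Trifluoromethyl in place of 2-fluoropyridin-3-yl

The source may report more compounds than this note shows. Statements on the series, on what has been measured and on what is new or still open speak of the compounds shown alone.

Within the data shown here, in an ADME assay on the whole organism (Mus musculus, strain Swiss Webster) for pharmacokinetics, read by LC-MS, at a dose of 50 mg/kg by the oral route (a lower number here means less compound in the circulation, a higher number more compound in the circulation at the dose given), compound 2 `O=C(Nc1ccc(F)c(-c2nc3ncc(-c4cccnc4F)cc3[nH]2)c1)N1CCCC1` gives 30900 ng.h/mL, the higher of the two numbers so far, while compound 1 `O=C(Nc1ccc(F)c(-c2nc3ncc(-c4cncc(F)c4)cc3[nH]2)c1)N1CCCC1` gives 1560 ng.h/mL. Among the measured compounds shown here, the single measured step, a 20-fold higher number from compound 1 to compound 2 (1.30 log units; beyond the scatter), exchanged 5-fluoropyridin-3-yl for 2-fluoropyridin-3-yl and shows that a change at this place can be large. Compound 3 `O=C(Nc1ccc(F)c(-c2nc3ncc(C(F)(F)F)cc3[nH]2)c1)N1CCCC1` carries trifluoromethyl in place of 2-fluoropyridin-3-yl on an aromatic carbon. For the measured compounds named here, no measured step removes this ring, so the evidence is indirect. The expected change is a 4.4-fold lower number from compound 2 to compound 3 (0.64 log units; beyond the scatter), with wide uncertainty. For compound 3 the estimated value is 7000 ng.h/mL, within an expected range of 1500 ng.h/mL to 30000 ng.h/mL.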

Compound 3, area under the concentration-time curve: 489 ng.h/mL
For compound 3 the middle estimate is 14-fold (1.16 log units) above the measured one; measured number outside the range, below it.
By their numbers in this assay, from the lowest: compound 3; then compound 1; then compound 2.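

In this assay, trifluoromethyl at this position gives a 63-fold lower number from compound 2 to compound 3 (1.80 log units; beyond the scatter) and a 3.2-fold lower number from compound 1 to compound 3 (0.50 log units; beyond the scatter), so compound 3 now has the lowest number of the three. Both fluoropyridinyl rings therefore stand above this non-ring group, though the loss is far larger from the 2-fluoropyridin-3-yl ring. Nothing available explains these drops. Among these compounds, with only one non-ring group at this position, the role of the ring itself remains open. An amine, a methoxy group or a carboxylic acid here would show whether other non-ring groups also fall below both rings.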